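A few compounds are considered here, and "the series" means these few. Any claim that something is new, unique, unknown or untested is made for them only; others in the source may bear on it.

Compound 1, `Cn1nc(-c2ccc(Cl)c(Cl)c2)n(C)c1=S`: 4.4 mg/kg
Compound 2, `Cn1nc(-c2cccc(C(F)(F)F)c2)n(C)c1=S`: > 200 mg/kg
Compound 3, `CCn1nc(-c2ccc(Cl)cc2)n(C)c1=S`: 100 mg/kg

In a functional assay on the whole organism with Mus musculus as the target (on this read-out higher numbers stand for an effect only at larger amounts of compound and lower numbers for an effect already at smaller amounts), compound 2 sits at a limit, > 200 mg/kg. This is the limit of > 200 mg/kg in this assay, at which 1 of the 3 values shown sits, so compound 2 has no number of its own, only a bound. In this assay compound 1 gives 4.4 mg/kg and compound 3 gives 100 mg/kg. Compound 4, `Cn1nc(-c2ccccc2)n(C)c1=S`, has not yet been measured; it differs from compound 2 by hydrogen in place of trifluoromethyl on an aromatic carbon. Going by the values given here, no measured pair so far differs in one place only, so the size of this step cannot be read from earlier steps. Given compound 2 at a bound, the expectation for this assay is a step of uncertain size, at best a modest move toward smaller doses, quite possibly none beyond the scatter. The estimate for compound 4 is 150 mg/kg, between 40 mg/kg and 400 mg/kg. That estimate means an expected step of an at least 1.3-fold lower number from compound 2 to compound 4 (0.12 log units; that floor lies within the scatter).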

Compound 4, dose for half-maximal effect: 0.13 mg/kg
Compound 4: middle estimate off by 1200-fold (3.06 log units), on the high side, outside the stated range (below it).
By their numbers in this assay, from the lowest: compound 4; then compound 1; then compound 3. At a limit, above all of these: compound 2.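

Replacing trifluoromethyl with hydrogen on this aromatic carbon gives an at least 1500-fold lower number from compound 2 to compound 4 (3.18 log units; beyond the scatter) in this assay, and this is the first change in one place only that can be read among these compounds. It shows that the group at this position matters greatly for the dose needed in the mouse. Compound 2 has only a bound, so the full size of the step remains unknown: the limit of > 200 mg/kg in this assay, at which 1 of the 4 values shown sits.

The compounds shown leave open whether a smaller group here, such as fluorine or methyl, would keep the result of compound 4. They also leave open how a methoxy group or an amine at this position would fare.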